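The source may hold more compounds than are shown below. What is called first, only, known or untested is meant among the compounds shown, and "the series" means these compounds.

Measured in a functional assay on DU-145 cells (Homo sapiens) for antiproliferative activity, read by WST assay, with a stated time of 3 days; on this read-out higher numbers stand for weaker inhibition and lower numbers for stronger inhibition:
- Compound 1 `CCCOc1c(-c2cc(OC)c(OC)c(OC)c2)oc2ccccc2c1=O`: 2800 nM
- Compound 2 `CCCCCOc1c(-c2cc(OC)c(OC)c(OC)c2)oc2ccccc2c1=O`: > 50000 nM, a limit
- Compound 3 `CCCN(CCC)CCCOc1c(-c2cc(OC)c(OC)c(OC)c2)oc2ccccc2c1=O`: > 50000 nM, a limit

Compound 3 has no number in this assay, only its limit of > 50000 nM. That places it at the limit of > 50000 nM in this assay, at which 2 of the 3 values shown sit. Compound 4 `CCCCCN(CCCCC)CCCOc1c(-c2cc(OC)c(OC)c(OC)c2)oc2ccccc2c1=O` differs from it as follows: dipentylamino in place of dipropylamino on a saturated chain carbon, three bonds along the chain from an oxygen on an aromatic ring.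

Among the compounds with values here, three measured steps bear on this change. Ethyl in place of hydrogen on the chain gave an at least 17-fold higher number from compound 1 to compound 2 (1.25 log units; beyond the scatter). Dipropylamino in place of hydrogen gave an at least 17-fold higher number from compound 1 to compound 3 (1.25 log units; beyond the scatter). Both are large and point towards weaker inhibition, while the third is a step that the two limits leave unreadable from compound 2 to compound 3. With the dipropylamino compound already at the limit, the data offer no sign of recovery, so no step beyond the scatter is expected, and a reported limit is the likeliest result. The estimate is a number no higher from compound 3 to compound 4 (the limit leaves the size open). For compound 4 the expected value is 50000 nM, with an estimated range from 15000 nM to 100000 nM.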

Compound 4, half-maximal inhibitory concentration: 12300 nM
Compound 4: middle estimate off by 4.1-fold (0.61 log units), on the high side, outside the stated range (below it).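

In this assay, the saturated chain carbon three bonds along the chain from an oxygen on an aromatic ring turned out not to be closed to a larger amino group: dipentylamino in place of dipropylamino gave an at least 4.0-fold lower number from compound 3 to compound 4 (0.60 log units; beyond the scatter), and dipentylamino in place of ethyl gave an at least 4.0-fold lower number from compound 2 to compound 4 (0.60 log units; beyond the scatter). The recovery is only partial, since dipentylamino in place of hydrogen still gave a 4.4-fold higher number from compound 1 to compound 4 (0.64 log units; beyond the scatter). Compound 2 and compound 3 remain limits, not numbers, so the full size of the two lower steps stays open: the limit of > 50000 nM in this assay, at which 2 of the 4 values shown sit.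

As far as these compounds go, whether the gain continues with a longer chain on the nitrogen, such as dihexylamino, remains open. So does the outcome for a cyclic amine such as piperidine or for a carboxylic acid at the end of the chain.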